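The source may report more compounds than this note shows. Statements on the series, on what has been measured and on what is new or still open speak of the compounds shown alone.

Measured in an ADME assay on SK-OV-3 cells (Homo sapiens) for cytotoxicity, read by sulforhodamine B assay, with a stated time of 48 h, tested at 10 uM; a higher number here means more inhibition at the concentration tested (going by the name of the read-out), a lower number less inhibition:
Compound 1, `COc1nc2ccc(Br)cc2cc1C(c1ccccc1)n1cc(C2CC2)nn1`, gives 3.52%.
Compound 2, `CCCCc1cn(C(c2ccccc2)c2cc3cc(Br)ccc3nc2OC)nn1`, gives 11.1%.
Compound 3, `COc1nc2ccc(Br)cc2cc1C(c1ccccc1)n1cc(-c2ccc(Br)cc2)nn1`, gives 13.4%.

Compound 3 holds the highest of the three numbers, yet its neighbours sit within the scatter: a number 2.3 percentage points higher from compound 2 to compound 3 (within the scatter) and a number 9.9 percentage points higher from compound 1 to compound 3 (within the scatter), and likewise a number 7.6 percentage points higher from compound 1 to compound 2 (within the scatter). Compound 4, `COc1nc2ccc(Br)cc2cc1C(c1ccccc1)n1cc(-c2cccc(F)c2)nn1`, is the next step from compound 3: 3-fluorophenyl in place of 4-bromophenyl on an aromatic carbon. Among the compounds with values here, no measured step swaps one aryl group for another at this position; the closest comparison is the move from butyl to 4-bromophenyl, which changed little. Every change so far at this aromatic carbon stayed inside the scatter, so compound 4 is expected to show no step beyond it, a number 3.4 percentage points lower from compound 3 to compound 4 (within the scatter). Compound 4 is therefore estimated at 10%, between 0% and 22%.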

Compound 4, a percentage reported as inhibition, at one concentration (the size of the read-out at that concentration, not a potency): 12.7%
Compound 4: middle estimate off by 2.7 percentage points, on the low side; the measured number falls inside the stated range.
By their numbers in this assay, from the lowest: compounds 1, 2, 4 and 3 (each within the scatter of the next).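

In this assay, exchanging one aryl group for another on this aromatic carbon, 3-fluorophenyl in place of 4-bromophenyl, gives a number 0.7 percentage points lower from compound 3 to compound 4 (within the scatter) and stays within the scatter. Set against butyl and cyclopropyl, the 3-fluorophenyl group gives a number 1.6 percentage points higher from compound 2 to compound 4 (within the scatter) and a number 9.2 percentage points higher from compound 1 to compound 4 (within the scatter), so all four groups shown at this position lie within the scatter of one another. Nothing measured here accounts for this. As far as these compounds go, whether an amine or a carboxylic acid at this position would move the number beyond the scatter remains open, as does the effect of any change elsewhere on the shared core.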